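Adding a third methoxy group to a chalcone-like pyrazole

The compounds below may be only part of what the source reports. "The series", "measured", "known", "first", "only" and "open" are said of these compounds alone.

Measured compounds:
- compound 1 `COc1cc(-c2cc(/C=C/C(=O)c3ccc(Cl)c(Cl)c3)[nH]n2)cc(OC)c1OC`: 105%
- compound 2 `COc1ccc(C(=O)/C=C/c2cc(-c3cc(OC)c(OC)c(OC)c3)n[nH]2)cc1OC`: 101%

In a functional assay on NCI-H460 cells (Homo sapiens) for cytotoxicity, read by sulforhodamine B assay, with a stated time of 48 h, tested at 0.1 uM (on this read-out higher numbers stand for a weaker effect at the one concentration tested and lower numbers for a stronger effect), compound 2 gives 101%, the lowest of the two numbers, with compound 1 nearest at a step of a number 4 percentage points lower from compound 1 to compound 2 (within the scatter). Compound 3 `COc1cc(C(=O)/C=C/c2cc(-c3cc(OC)c(OC)c(OC)c3)n[nH]2)cc(OC)c1OC` differs from compound 2 by methoxy in place of hydrogen on an aromatic carbon. Within the data shown here, the single measured step, a swap of 3,4-dimethoxyphenyl for 3,4-dichlorophenyl on the carbonyl carbon, gave a number 4 percentage points lower from compound 1 to compound 2 (within the scatter), so it offers no sign that a change at this ring moves the read-out. Compound 3 is therefore expected to show no step beyond the scatter, a number 1 percentage points lower from compound 2 to compound 3 (within the scatter), with an estimated value of 100%, between 86% and 112%.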

Compound 3, a percentage reported as activity, at one concentration (the size of the read-out at that concentration, not a potency): 104%
Compound 3: the middle estimate sits 4 percentage points below what was measured, within the range that was stated.
By their numbers in this assay, from the lowest: compounds 2, 3 and 1 (each within the scatter of the next).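

In this assay, methoxy in place of hydrogen on this aromatic carbon, ortho to a methoxy group, gives a number 3 percentage points higher from compound 2 to compound 3 (within the scatter). The earlier step changed two groups on this ring at once, whereas this one shows that a single added methoxy here also leaves the read-out within the scatter at the one concentration tested. No measurement is available that bears on the reason for this result. From the compounds shown here alone, whether an amine or a carboxylic acid on this same aromatic carbon would move the read-out remains open. So does whether the added methoxy would matter at any other concentration.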